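A few compounds are considered here, and "the series" means these few. Any claim that something is new, unique, unknown or untested is made for them only; others in the source may bear on it.

In a functional assay on HepG2 cells (Homo sapiens) for inhibition, read by MTT assay, with a stated time of 72 h (a lower number here means a stronger inhibitor, a higher number a weaker inhibitor), compound 3 `Nc1nc2cc(-c3nn(CCC(=O)NO)c4ncnc(N)c34)ccc2o1` gives > 150000 nM, which is a limit and not a number. Compound 1 `Nc1ncnc2c1c(-c1cnc3[nH]ccc3c1)nn2CC(=O)NO` gives > 150000 nM, likewise a limit. Compound 2 `Nc1ncnc2c1c(-c1cnc3[nH]ccc3c1)nn2CCCCCCCCCC(=O)NO` is the only one of the three to return a number, at 11700 nM. Compound 4 `Nc1nc2cc(-c3nn(CCCCCCC(=O)NO)c4ncnc(N)c34)ccc2o1` differs from compound 3 by 4-(hydroxycarbamoyl)butyl in place of hydroxycarbamoyl on a saturated chain carbon, two bonds along the chain from an aromatic nitrogen, so that 2-(hydroxycarbamoyl)ethyl becomes 6-(hydroxycarbamoyl)hexyl. Among the measured compounds shown here, no measured step is available, so the expectation rests on the long-chained compound 2 at 11700 nM. Stronger inhibition in this assay, beyond the scatter, is expected, with an estimated at least 10-fold lower number from compound 3 to compound 4 (1.00 log units; beyond the scatter). Compound 4 is expected at about 15000 nM, within an estimated range of 3000 nM to 80000 nM.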

Compound 4, half-maximal inhibitory concentration: 1610 nM
Compound 4: middle estimate off by 9.3-fold (0.97 log units), on the high side; the whole stated range lies above it.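

In this assay, among the compounds shown here, replacing 2-(hydroxycarbamoyl)ethyl with 6-(hydroxycarbamoyl)hexyl on this saturated chain carbon gives an at least 93-fold lower number from compound 3 to compound 4 (1.96 log units; beyond the scatter), the first comparison here of two compounds that differ in one place. It shows that, on this core, the length of the chain carrying the hydroxycarbamoyl end separates a limit from a measured number. The step is itself a bound, since compound 3 stands at a limit: the limit of > 150000 nM in this assay, at which 2 of the 4 values shown sit.

The compounds shown leave open whether a longer chain would lower the number further, and whether a carboxylic acid could replace the hydroxycarbamoyl end on the hexyl chain.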